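The compounds below may be only part of what the source reports. "The series", "measured", "known", "first", "only" and "open" are said of these compounds alone.

Compound 2 `CC(C)=CCC1Cc2c(OCCCNC(=O)c3ccco3)cc(=O)n(CCCO)c2CC1(C)C` sits lowest of the three measured compounds in a functional assay on PANC-1 cells (Homo sapiens) for inhibition, read by MTT assay, with a stated time of 24 h, tested at 10 uM (on this read-out higher numbers stand for more inhibition at the one concentration tested (going by the name of the read-out) and lower numbers for less inhibition), giving 2.1%. Compound 3 `COc1ccc(OCCCOc2cc(=O)n(CCCO)c3c2CC(CC=C(C)C)C(C)(C)C3)cc1` gives 47.7%, and compound 1 `CCOc1cc(=O)n(CCCO)c2c1CC(CC=C(C)C)C(C)(C)C2` gives 66.5%. The change to compound 4 `COc1ccccc1NC(=O)Oc1cc(=O)n(CCCO)c2c1CC(CC=C(C)C)C(C)(C)C2` is (2-methoxyphenyl)carbamoyl in place of 3-(((furan-2-yl)carbonyl)amino)propyl on an oxygen on an aromatic ring. Among the compounds with values here, two measured steps touch the same chain: adding the furan amide to the chain gave a number 64.4 percentage points lower from compound 1 to compound 2 (beyond the scatter), and swapping it for a methoxyphenoxy group gave a number 45.6 percentage points higher from compound 2 to compound 3 (beyond the scatter). Within the data shown here, both point to the furan amide going with low inhibition, so losing it is expected to raise the number, though no measured compound carries a carbamoyl on this oxygen. Compound 4 is therefore expected to show a number 37.9 percentage points higher from compound 2 to compound 4 (beyond the scatter), landing near 40% within 15% to 68%.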

Compound 4, a percentage reported as inhibition, at one concentration (the size of the read-out at that concentration, not a potency): 71.1%
Estimate against measurement, compound 4: 31.1 percentage points below; the whole stated range lies below it.
By their numbers in this assay, from the lowest: compound 2; then compound 3; then compounds 1 and 4 (each within the scatter of the next).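

In this assay the oxygen on an aromatic ring carries a (2-methoxyphenyl)carbamoyl group without any loss against the ethyl of compound 1, with a number 4.6 percentage points higher from compound 1 to compound 4 (within the scatter) as the step. Replacing 3-(((furan-2-yl)carbonyl)amino)propyl with this group gives a number 69 percentage points higher from compound 2 to compound 4 (beyond the scatter) even though both groups hold 11 heavy atoms, so that count alone does not separate compound 2 from compound 4.

Nothing measured here explains this difference. As far as these compounds go, it also remains open whether a carboxylic acid or an amine in place of the methoxy group would keep inhibition at this level.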